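From Benzyloxy to Amino on a Carbonyl Carbon

The source may report more compounds than this note shows. Statements on the series, on what has been measured and on what is new or still open speak of the compounds shown alone.

Of the compounds shown here, three have been tested so far in a functional assay on Raji cells (Homo sapiens) for cytotoxicity, with a stated time of 72 h; on this read-out higher numbers stand for an effect only at larger amounts of compound and lower numbers for an effect already at smaller amounts. Compound 1 `C=C[C@@](C)(/C=C/c1ccc(O)c(C=O)c1)CCC=C(C)C` reads > 26000 nM, which is a limit and not a number. Compound 2 `C=C[C@@](C)(/C=C/c1ccc(O)c(/C=C/C(=O)c2ccccc2)c1)CCC=C(C)C` reads > 26000 nM, also a limit. Compound 3 `C=C[C@@](C)(/C=C/c1ccc(O)c(/C=C/C(=O)OCc2ccccc2)c1)CCC=C(C)C` reads > 26000 nM, again only a limit. The series therefore shows (the limit of > 26000 nM in this assay, at which 3 of the 3 values shown sit), and compound 3 stands there without a number. Compound 4 `C=C[C@@](C)(/C=C/c1ccc(O)c(/C=C/C(N)=O)c1)CCC=C(C)C` differs from compound 3 by amino in place of benzyloxy on a carbonyl carbon. Among the compounds with values here, the only measured step that bears on this change is a step that the two limits leave unreadable from compound 2 to compound 3. Because a step that the two limits leave unreadable from compound 2 to compound 3 offers no size to build on, no clear shift in either direction is expected. The expected step in this assay is a step that the limit leaves unreadable from compound 3 to compound 4, and another limit is likely. For compound 4 the estimated value is 30000 nM, within a range from 12000 nM to 60000 nM overall.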

Compound 4, half-maximal effective concentration: > 26000 nM
Compound 4 was reported as a limit; the forecaster's own chance of this, stated with the estimate: 85%; the middle value does not contradict the limit.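

Within the data shown here, compound 4 is again reported only as a limit, like compound 1, compound 2 and compound 3, so no step among them can be read: the limit of > 26000 nM in this assay, at which 4 of the 4 values shown sit. The compounds shown leave open whether any of them has a measurable effect on these cells, and how large it would be.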